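Methyl to Hydrogen on a Phenol Oxygen, Carried to a Second Core

The compounds below may be only part of what the source reports. "The series", "measured", "known", "first", "only" and "open" are said of these compounds alone.

Compound 1, `COc1cc(-c2nn(-c3cccc(NC(=O)Nc4cc(C(F)(F)F)cc(C(F)(F)F)c4)c3)cc2-c2ccncc2)ccc1Cl`: 858 nM
Compound 2, `O=C(Nc1cccc(-n2cc(-c3ccncc3)c(-c3ccc(Cl)c(O)c3)n2)c1)Nc1cc(C(F)(F)F)cc(C(F)(F)F)c1`: 877 nM
Compound 3, `COc1cc(-c2nn(-c3cccc(NC(=O)Nc4ccc(Cl)c(C(F)(F)F)c4)c3)cc2-c2ccncc2)ccc1Cl`: 1280 nM

Of the compounds shown here, three have been measured in a functional assay on SNB-75 cells (Homo sapiens) for inhibition, read by sulforhodamine B assay, with a stated time of 48 h; on this read-out lower numbers stand for stronger inhibition of growth and higher numbers for weaker inhibition of growth. Compound 1 and compound 2 differ in one place only: hydrogen in place of methyl on an oxygen on an aromatic ring. That change produced a 1.0-fold higher number from compound 1 to compound 2 (0.01 log units; within the scatter), so the two compounds cannot be told apart on this read-out.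

Compound 3 carries the same methoxy group as compound 1 but sits on a different core; the difference between the two cores is not broken down here. Compound 3 and compound 2 give numbers that, like all three measured values, lie within the usual scatter of one another, so no ordering among them can be claimed.

The unmeasured compound is compound 4, `O=C(Nc1cccc(-n2cc(-c3ccncc3)c(-c3ccc(Cl)c(O)c3)n2)c1)Nc1ccc(Cl)c(C(F)(F)F)c1`. It differs from compound 3 by hydrogen in place of methyl on an oxygen on an aromatic ring. The place of the change is described in the same words for both pairs, so this is the same change, now made on the core of compound 3 rather than the core of compound 1.

Because the earlier instance gave a 1.0-fold higher number from compound 1 to compound 2 (0.01 log units; within the scatter), the expectation is that the step from compound 3 to compound 4 will also be flat, and the estimated step is a 1.0-fold higher number from compound 3 to compound 4 (0.01 log units; within the scatter). Compound 4 is therefore expected to give about 1300 nM in this assay, with a likely range from 650 nM to 2600 nM.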

Compound 4, concentration for 50% growth inhibition: 678 nM
Compound 4: the middle estimate sits 1.9-fold (0.28 log units) above what was measured; the range from low to high includes it.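

In this assay, exchanging methoxy for hydroxy on the core of compound 3 gave a 1.9-fold lower number from compound 3 to compound 4 (0.28 log units; within the scatter), so this pair, like the first, cannot be separated on this read-out. Set side by side, the two instances of the change show no difference that can be trusted: the same change on two cores in this assay, a 1.0-fold higher number (0.01 log units; within the scatter) from compound 1 to compound 2 and a 1.9-fold lower number (0.28 log units; within the scatter) from compound 3 to compound 4, 1.9-fold (0.29 log units) apart, within the scatter of two such steps What this shows is modest but useful: in both pairs, 4-chloro-3-methoxyphenyl and 4-chloro-3-hydroxyphenyl could be exchanged without a step beyond the normal variation of the measurement, and the outcome on the core of compound 1 carried over to the core of compound 3; it does not show that the change has no effect at all, since a small effect could be hidden within the scatter, and two pairs cannot establish a rule for the whole series.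

The compounds shown leave open what happens when the oxygen carries a longer chain, as in ethoxy, or when an amine or a carboxylic acid stands in place of the hydroxy. They also leave open whether the same exchange would stay this quiet on further cores or in other cell lines.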